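This account rests on a few compounds, and the source may have more. Where it says the series, first, only, none or still open, it means among the compounds named here.

Working notes on the series. The shared core is that of compound 1 `O=C1C(N2CCCCC2)=CC(=O)c2c1nc1n2[C@H]2OC[C@@H](O)[C@H]2OC1`, which in a functional assay on ECa-109 cells for inhibition, with ECa-109 cell line (Homo sapiens) as the target, read by sulforhodamine B assay (a higher number here means a weaker inhibitor, a lower number a stronger inhibitor), returns only a limit of the assay, > 8000 nM. Compound 2 `O=C1C=C(N2CCCCC2)C(=O)c2c1nc1n2[C@H]2OC[C@@H](O)[C@H]2OC1` likewise gives only a limit in this assay, > 8000 nM. Compound 3 `O=C1C(Nc2ccc(C(F)(F)F)cc2)=CC(=O)c2c1nc1n2[C@H]2OC[C@@H](O)[C@H]2OC1`, with an anilino-type substituent carrying trifluoromethyl, is the one entry with a measured number in this assay, 2250 nM. Compound 1 thus stands at the limit of > 8000 nM in this assay, at which 2 of the 3 values shown sit, and no more than that is known of its position.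

Compound 4 `CCCN(CCC)C1=CC(=O)c2c(nc3n2[C@H]2OC[C@@H](O)[C@H]2OC3)C1=O` differs from compound 1 by dipropylamino in place of piperidin-1-yl on a double-bonded ring carbon. For the measured compounds named here, no measured step between two compounds is available, so the size of this change cannot be read from a neighbouring pair. Both amino-substituted entries, compound 1 and compound 2, sit at the limit, and a dipropylamino group is expected to behave in the same way. The step that the limit leaves unreadable from compound 1 to compound 4 is expected to be small, nothing beyond the usual scatter. Compound 4 is expected to give 10000 nM in this assay, within 4000 nM to 25000 nM, most probably reported again only as a limit.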

Compound 4, half-maximal inhibitory concentration: > 16000 nM
Compound 4 was reported as a limit; the forecaster's own chance of this, stated with the estimate: 70%; at least 1.6-fold (0.20 log units) between middle value and limit.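

For the compounds shown here, compound 1 and compound 4 both stand only as limits in this assay, so no step between them can be read. The compounds shown leave open the actual values of compound 1 and compound 4 in this assay, and with them the size of the change from piperidin-1-yl to dipropylamino.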